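The compounds below may be only part of what the source reports. "The series", "measured", "known", "first", "only" and "open" are said of these compounds alone.

Of the compounds shown here, three of a shared core have so far been measured in a functional assay on HCT-116 cells (Homo sapiens) for cytotoxicity, read by MTT assay, with a stated time of 48 h, in the presence of a further agent that is not named here; on this read-out lower numbers stand for an effect already at smaller amounts and higher numbers for an effect only at larger amounts of compound. Compound 1 `Cc1nn(C)c2nc(NNC(=O)Nc3cc(Cl)nc(Cl)c3)cc(-c3ccc(Cl)s3)c12` gives 42100 nM in this assay. Compound 2 `COc1ccc(-c2cc(NNC(=O)Nc3cc(Cl)nc(OC)c3)nc3c2cnn3C)cc1` gives 54200 nM in this assay, and compound 3 `COc1cc(NC(=O)NNc2cc(-c3ccc(F)cc3)c3cnn(C)c3n2)cc(Cl)n1` gives 75300 nM in this assay. The three numbers sit close together: compound 2 lies within the scatter of compound 1 and within the scatter of compound 3, so no order among them can be read from these data. For the measured compounds named here, the only single-point step so far, a 1.4-fold higher number from compound 2 to compound 3 (0.14 log units; within the scatter), concerns the aryl ring on the core and lies within the scatter.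

Compound 4 `CCCOc1cc(NC(=O)NNc2cc(-c3ccc(OC)cc3)c3cnn(C)c3n2)cc(Cl)n1` differs from compound 2 as follows: ethyl in place of hydrogen on a saturated chain carbon bound to an oxygen on an aromatic ring. Going by the values given here, no measured pair changes this alkoxy group on the chloropyridine, so the data offer no direct guide; the one step available, from compound 2 to compound 3, shows only that a change elsewhere on the molecule left this assay unmoved. The reading for compound 4 in this assay is therefore expected to stay close to that of compound 2, with a step of about a 1.0-fold higher number from compound 2 to compound 4 (0.01 log units; within the scatter) and nothing beyond the scatter foreseen. Compound 4 is estimated at 55000 nM in this assay, within a range from 25000 nM to 120000 nM.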

Compound 4, half-maximal effective concentration: 33300 nM
Estimate against measurement, compound 4: 1.7-fold (0.22 log units) above; low and high end bracket the measured number.
By their numbers in this assay, from the lowest: compounds 4, 1, 2 and 3 (each within the scatter of the next, the first and the last beyond it).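

For the compounds shown here, the pair of compound 2 and compound 4 is the first to touch the alkoxy group on the chloropyridine, where methoxy becomes propoxy; in this assay it gives a 1.6-fold lower number from compound 2 to compound 4 (0.21 log units; within the scatter) and so lies within the scatter. The earlier step, a 1.4-fold higher number from compound 2 to compound 3 (0.14 log units; within the scatter), concerned only the aryl ring on the core, so this result adds a second site at which a single change leaves the reading inside the scatter, here with an ethyl added to the saturated chain carbon bound to the oxygen on the aromatic ring. Nothing at hand speaks to what lies behind the size of this step.

With one step at this position, the result describes only the move from methoxy to propoxy and gives no trend along a series of chains, so a longer chain such as butoxy, a branched isopropoxy or an amine in place of the alkoxy group remains an open case. Going by these compounds alone, it also remains open whether propoxy would read the same alongside the fluorophenyl group of compound 3, since the change has been seen only with the methoxyphenyl group of compound 2.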